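Hydroxy for Trifluoromethoxy on the Aryl Quinolone Ester

A few compounds are considered here, and "the series" means these few. Any claim that something is new, unique, unknown or untested is made for them only; others in the source may bear on it.

Compound 1, `CCOC(=O)c1c(-c2ccccc2)[nH]c2cc(OC)ccc2c1=O`: > 22000 nM in an ADME assay on HEK293 cells (Homo sapiens) for cytotoxicity, read by luminescence, with a stated time of 72 h (a higher number here means that more compound is needed for the effect, a lower number that less compound is needed), a limit of the assay.
Compound 2, `CCOC(=O)c1c(-c2cccc(OC(F)(F)F)c2)[nH]c2cc(OC)ccc2c1=O`: > 22000 nM in this assay, a limit of the assay.

Compound 2 stands at the limit of this assay, with no number read for it. Within the data shown here, the only measured step, trifluoromethoxy in place of hydrogen on an aromatic carbon, is a step that the two limits leave unreadable from compound 1 to compound 2, so it gives no size. The two values shown share (the limit of > 22000 nM in this assay, at which 2 of the 2 values shown sit), which is the whole of the evidence.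

Compound 3, `CCOC(=O)c1c(-c2cccc(O)c2)[nH]c2cc(OC)ccc2c1=O`, differs from compound 2 by hydrogen in place of trifluoromethyl on an oxygen on an aromatic ring. Among the measured compounds shown here, no measured step bears on this change, and the pair before it left no readable step, so there is no ground to expect a step beyond the scatter in this assay in either direction. Compound 3 is therefore expected to sit where compound 2 sits, at the limit, so that the expected step that the limit leaves unreadable from compound 2 to compound 3 is none. The estimate for compound 3 in this assay is 30000 nM, with a range of 12000 nM to 90000 nM.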

Compound 3, half-maximal effective concentration: > 22000 nM
Compound 3 gave a limit, no number; the forecaster's own chance of this, stated with the estimate: 80%; the middle value does not contradict the limit.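

In this assay compound 3 gives > 22000 nM, a limit of the assay. No new step can be read from compound 1 or compound 2 to compound 3. The compounds shown leave open what number each of the three would have, and so whether hydroxy, trifluoromethoxy or hydrogen makes any difference in this assay: the limit of > 22000 nM in this assay, at which 3 of the 3 values shown sit.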